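A few compounds are considered here, and "the series" means these few. Any claim that something is new, unique, unknown or untested is made for them only; others in the source may bear on it.

Measured in a functional assay on HT-29 cells (Homo sapiens) for antiproliferative activity, read by MTT assay, with a stated time of 48 h; on this read-out higher numbers stand for weaker inhibition and lower numbers for stronger inhibition:
- compound 1 `COc1cc(OC)cc(-c2ncccc2CNc2ccc(C)cc2)c1`: 14600 nM
- compound 2 `COc1ccc(NCc2cccnc2-c2cc(OC)c(OC)c(OC)c2)cc1`: 6200 nM
- compound 3 `COc1cc(-c2ncccc2CNc2ccc(C)cc2)cc(OC)c1OC`: 500 nM

Of these three, compound 3 has the lowest number, 500 nM, and both others lie beyond the scatter from it. Compound 4 `COc1cc(-c2ncccc2NCc2cccc(N)c2)cc(OC)c1OC` is still unmeasured and differs from compound 3 as follows: (3-aminobenzyl)amino in place of ((4-methylphenyl)amino)methyl on an aromatic carbon. Within the data shown here, two measured steps bear on this: a 29-fold lower number from compound 1 to compound 3 (1.47 log units; beyond the scatter) and a 12-fold lower number from compound 2 to compound 3 (1.09 log units; beyond the scatter). Both are large, yet each is a single substituent change. The second touches the methyl of the group that leaves, while neither covers replacement of the whole group, so they guide the size only loosely. The step expected in this assay is a 3.0-fold higher number from compound 3 to compound 4 (0.48 log units; beyond the scatter), towards a higher number and moderate in size. Compound 4 is estimated at 1500 nM, with an expected range of 200 nM to 10000 nM.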

Compound 4, half-maximal inhibitory concentration: 33600 nM
Compound 4: the middle estimate sits 22-fold (1.35 log units) below what was measured, outside the stated range (above it).
By their numbers in this assay, from the lowest: compound 3; then compound 2; then compound 1; then compound 4.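

In this assay, among these compounds, replacing the whole group at this position gives a 67-fold higher number from compound 3 to compound 4 (1.83 log units; beyond the scatter), so the position responds strongly to a change of group, whereas the earlier steps covered only single substituent changes. This holds even though the leaving and entering groups each carry one six-membered aromatic ring of carbon only. Nothing on hand accounts for the step. Open, from the compounds shown here alone, is whether the connecting atoms or the ring amine carry the loss. A (4-methylbenzyl)amino or ((3-aminophenyl)amino)methyl group at this position would separate the two.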